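From chloromethyl to 4-fluorophenyl on the shared core

The compounds below may be only part of what the source reports. "The series", "measured", "known", "first", "only" and "open" are said of these compounds alone.

Compound 2 `C/C(=N\Nc1nc(CCl)cs1)c1ccc(Cl)c(Cl)c1` reads > 50000 nM in an ADME assay on J774 cells (Mus musculus) for cytotoxicity, read by resazurin assay, with a stated time of 72 h (on this read-out higher numbers stand for lower toxicity in this test and lower numbers for higher toxicity in this test), which is a limit and not a number. Compound 1 `C/C(=N\Nc1nc(C)cs1)c1ccc(Cl)c(Cl)c1` gives 33700 nM in this assay. Among the compounds with values here, the one measured step is an at least 1.4-fold higher number from compound 1 to compound 2 (0.17 log units; that floor lies within the scatter). Compound 3 `C/C(=N\Nc1nc(-c2ccccc2)c(C)s1)c1ccc(Cl)c(Cl)c1` reads > 50000 nM, again a limit. Compound 2 therefore stands with compound 3 at the limit of > 50000 nM in this assay, at which 2 of the 3 values shown sit.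

Compound 4 `C/C(=N\Nc1nc(-c2ccc(F)cc2)cs1)c1ccc(Cl)c(Cl)c1` differs from compound 2 by 4-fluorophenyl in place of chloromethyl on an aromatic carbon. Within the data shown here, no measured step covers this change, so no shift beyond the scatter is expected, and any shift would be towards lower numbers. The expected step is an at least 1.1-fold lower number from compound 2 to compound 4 (0.07 log units; that floor lies within the scatter). For compound 4 the estimated value is 42000 nM, with an expected range of 18000 nM to 50000 nM.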

Compound 4, half-maximal cytotoxic concentration: > 50000 nM
Compound 4 gave a limit, no number; the forecaster's own chance of this, stated with the estimate: 45%; middle value at least 1.1-fold (0.07 log units) away from the limit.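

In this assay compound 4 also ends at a limit, not a number: the limit of > 50000 nM in this assay, at which 3 of the 4 values shown sit.

On the aromatic carbon next to the ring nitrogen, 4-fluorophenyl in place of methyl gives an at least 1.4-fold higher number from compound 1 to compound 4 (0.17 log units; that floor lies within the scatter), so this six-membered aromatic ring shows no sign of higher toxicity in this test. The step between compound 2 and compound 4 cannot be read, since both values are limits.

Going by these compounds, the true values of compound 2 and compound 4 remain open. Also open, on these data alone, is whether an amine or a carboxylic acid on this carbon would give a number rather than a limit.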